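Adding a Methyl Group to Difluoromethylbenzene

A few compounds are considered here, and "the series" means these few. Any claim that something is new, unique, unknown or untested is made for them only; others in the source may bear on it.

Within the data shown here, compound 2 `FC(F)c1ccccc1` stands highest of the two numbers measured so far in a physicochemical assay for lipophilicity, read by spectrophotometry, using the shake flask method, measured as octanol-water partition (on this read-out lower numbers stand for lower lipophilicity and higher numbers for higher lipophilicity), where compound 2 gives 2.4. Its nearest neighbour is compound 1 `O=[N+]([O-])c1ccc(C(F)F)cc1`, which in this assay gives 2.12; the step of a number 0.28 log units higher from compound 1 to compound 2 (within the scatter) lies within the scatter. Compound 3 `Cc1ccc(C(F)F)cc1` differs from compound 2 by methyl in place of hydrogen on an aromatic carbon. Among the measured compounds shown here, no measured step matches this change: the only step known, a number 0.28 log units higher from compound 1 to compound 2 (within the scatter), concerns the exchange of a nitro group for a hydrogen and not the entry of a methyl, so it offers no direct guide to the size or direction of the new step. The expectation for compound 3 therefore rests on the structural change alone, and a modest rise is expected, a number 0.50 log units higher from compound 2 to compound 3 (beyond the scatter). On that basis compound 3 is estimated at 2.9 in this assay, with a range from 2.6 to 3.2.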

Compound 3, partition coefficient: 2.94
For compound 3 the middle estimate is 0.04 log units below the measured one; the measured number falls inside the stated range.
By their numbers in this assay, from the lowest: compounds 1 and 2 (each within the scatter of the next); then compound 3.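

In this assay, methyl on the aromatic carbon para to a difluoromethyl group gives the first step from the hydrogen compound that lies beyond the scatter, a number 0.54 log units higher from compound 2 to compound 3 (beyond the scatter). Set against the nitro compound, the same place gives a number 0.82 log units higher from compound 1 to compound 3 (beyond the scatter), so compound 3 stands clear of both compound 1 and compound 2, which themselves remain within the scatter of each other. Nothing available accounts for the size of these steps.

The compounds shown leave open whether a longer chain such as ethyl would extend the methyl step at this place, and where an amine or a carboxylic acid would fall on the same read-out. With one methyl pair on a single core, they also leave open whether this step would hold in the absence of the difluoromethyl group.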